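The source may report more compounds than this note shows. Statements on the series, on what has been measured and on what is new or still open speak of the compounds shown alone.

In a functional assay on A549 cells (Homo sapiens) for antiproliferative activity, read by MTT assay, with a stated time of 48 h (a higher number here means a weaker inhibitor, a lower number a stronger inhibitor), compound 1 (`COCOC/C1=C/C[C@](C)(CCC=C(C)C)/C=C/[C@@H](OC(=O)C=C(C)C)[C@](C)(O)/C=C/C1=O`) reads 2980 nM and compound 2 (`CC(C)=CCC[C@]1(C)/C=C/[C@@H](OC(=O)C=C(C)C)[C@](C)(O)/C=C/C(=O)/C(Cn2cc(CO)nn2)=C\C1`) reads 3470 nM on the same scale. The step between them is a 1.2-fold higher number from compound 1 to compound 2 (0.07 log units; within the scatter) and leaves the two level.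

Going by the values given here, compound 3 (`CC(C)=CCC[C@]1(C)/C=C/[C@@H](OC(=O)C=C(C)C)[C@](C)(O)/C=C/C(=O)/C(C(=O)N(C(C)C)C(C)C)=C\C1`) has the highest number of the three at 13500 nM in this assay so far. It is reached by a 4.5-fold higher number from compound 1 to compound 3 (0.66 log units; beyond the scatter) and by a 3.9-fold higher number from compound 2 to compound 3 (0.59 log units; beyond the scatter) as its two modest steps.

Compound 4 (`CC(C)=CCC[C@]1(C)/C=C/[C@@H](OC(=O)C=C(C)C)[C@](C)(O)/C=C/C(=O)/C(C(=O)N2CCCC2)=C\C1`) changes one place of compound 3: pyrrolidin-1-yl in place of diisopropylamino on a carbonyl carbon with pyrrolidin-1-yl in place of diisopropylamino on a carbonyl carbon.

Among the compounds with values here, no measured step varies the amine on this carbonyl, so the two modest steps into compound 3 bear only indirectly and set an upper scale for the change. A small fall in this assay is expected, probably not beyond the scatter, since compound 3 at 13500 nM stands above both other compounds.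

The estimate means a 1.7-fold lower number from compound 3 to compound 4 (0.23 log units; within the scatter) as the expected step.

For compound 4 the estimated value is 8000 nM with an expected range of 3500 nM to 18000 nM in this series.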

Compound 4, half-maximal inhibitory concentration: 13000 nM
Compound 4: the middle estimate sits 1.6-fold (0.21 log units) below what was measured; the measured number falls inside the stated range.
By their numbers in this assay, from the lowest: compounds 1 and 2 (each within the scatter of the next); then compounds 4 and 3 (each within the scatter of the next).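

In this assay, pyrrolidin-1-yl in place of diisopropylamino on a carbonyl carbon leaves the two amides level (a 1.0-fold lower number from compound 3 to compound 4 (0.02 log units; within the scatter)), so this first change to the amine, from an open branched group to a five-membered non-aromatic ring, does not move the number. The gap to the two compounds without this carbonyl also holds for the new amide (a 3.7-fold higher number from compound 2 to compound 4 (0.57 log units; beyond the scatter)) (a 4.4-fold higher number from compound 1 to compound 4 (0.64 log units; beyond the scatter)), as it did for compound 3. Nothing available bears on why the amine change leaves the number level.

Still open, on these data alone, is whether any amine on this carbonyl would bring the number down to the level of compound 1 and compound 2. A morpholin-4-yl amide, a secondary amide keeping the amide hydrogen or a free carboxylic acid on the double-bonded ring carbon would test this.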